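The source may hold more compounds than are shown below. What is called first, only, known or untested is meant among the compounds shown, and "the series" means these compounds.

In a functional assay, with a stated time of 30 min (on this read-out higher numbers stand for weaker inhibition and lower numbers for stronger inhibition), compound 1 `O=C(/C=C/c1cc(O)ccc1O)CC(=O)/C=C/c1cc(O)ccc1O` gives 57000 nM and compound 2 `O=C(/C=C/c1ccccc1O)/C=C/c1cccc(O)c1O` gives 99000 nM on the same read-out. For the measured compounds named here, these two numbers lie within the usual scatter of each other, so compound 2 stands level with compound 1 among the only measurements available so far. Compound 3 `O=C(/C=C/c1cccc(O)c1)/C=C/c1cccc(O)c1O` remains unmeasured. It differs from compound 2 by 3-hydroxyphenyl in place of 2-hydroxyphenyl on a double-bonded chain carbon bound to a double-bonded chain carbon in a single place, with 3-hydroxyphenyl in place of 2-hydroxyphenyl on a double-bonded chain carbon bound to a double-bonded chain carbon. Going by the values given here, no measured pair differing in one place is available as a guide, so no shift beyond the scatter is expected in this assay and the estimate stands at a 1.2-fold lower number from compound 2 to compound 3 (0.09 log units; within the scatter) for this change. For compound 3 the expected value is 80000 nM with an estimated range from 30000 nM to 200000 nM in this measurement.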

Compound 3, half-maximal inhibitory concentration: 48000 nM
Compound 3: the middle estimate sits 1.7-fold (0.22 log units) above what was measured; the range from low to high includes it.
By their numbers in this assay, from the lowest: compounds 3, 1 and 2 (each within the scatter of the next, the first and the last beyond it).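

In this assay, for the compounds shown here, the swap of 2-hydroxyphenyl for 3-hydroxyphenyl on a double-bonded chain carbon bound to a double-bonded chain carbon gives a 2.1-fold lower number from compound 2 to compound 3 (0.31 log units; beyond the scatter), the first step here between compounds differing in one place. The two groups have the same atoms and the same counts of hydrogen-bond donors and acceptors, so the read-out at this place responds to how the group is joined, not only to what it contains, though the step is modest. Nothing at hand accounts for this shift.

Going by these compounds, what remains open is whether this place tolerates a group other than a hydroxyphenyl, such as a methoxyphenyl, an aminophenyl or a plain phenyl. This single step also leaves open whether the same swap would have a similar effect on the other ring of the shared core.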